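This account rests on a few compounds, and the source may have more. Where it says the series, first, only, none or still open, it means among the compounds named here.

Measured so far in a functional assay (trachea) with Cavia porcellus as the target; a lower number here means that less compound is needed, a higher number that more compound is needed for the effect:
- Compound 1 `C=CCn1c(=O)c2[nH]cnc2n(CCC)c1=O`: 1600 nM
- Compound 2 `C=CCCn1c(=O)c2[nH]cnc2n(CCC)c1=O`: 200 nM
- Compound 3 `CCCn1c(=O)n(CC(=O)O)c(=O)c2[nH]cnc21`: 41000 nM

Still unmeasured: compound 4 `CCCn1c(=O)n(CCC(=O)O)c(=O)c2[nH]cnc21`.

Of the three measured compounds, compound 3 has the highest number (41000 nM), so it needs the most compound for the effect. Going to compound 4 puts carboxymethyl in place of carboxy on a saturated chain carbon bound to an aromatic nitrogen. Within the data shown here, the nearest precedent is a modest step (an 8.0-fold lower number from compound 1 to compound 2 (0.90 log units; beyond the scatter)), with allyl in place of vinyl at that place. Two large steps (a 26-fold higher number from compound 1 to compound 3 (1.41 log units; beyond the scatter) and a 210-fold higher number from compound 2 to compound 3 (2.31 log units; beyond the scatter)) came with carboxy in place of those groups, and compound 4 still carries the acid. In this assay a smaller fall is therefore expected (a 2.6-fold lower number from compound 3 to compound 4 (0.41 log units; beyond the scatter)). Compound 4 is estimated at 16000 nM with an expected range from 4000 nM to 60000 nM overall.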

Compound 4, half-maximal effective concentration: 21200 nM
Compound 4: the middle estimate sits 1.3-fold (0.12 log units) below what was measured; low and high end bracket the measured number.
By their numbers in this assay, from the lowest: compound 2; then compound 1; then compounds 4 and 3 (each within the scatter of the next).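

In this assay, carboxymethyl in place of carboxy leaves the two acids within the scatter of each other, at a 1.9-fold lower number from compound 3 to compound 4 (0.29 log units; within the scatter). The longer acid chain still needs far more compound than the chains ending in a carbon-carbon double bond, with a 110-fold higher number from compound 2 to compound 4 (2.03 log units; beyond the scatter) and a 13-fold higher number from compound 1 to compound 4 (1.12 log units; beyond the scatter). The penalty for bringing in the acid nevertheless depends on the chain length it is compared at: the same change on two cores in this assay, a 26-fold higher number (1.41 log units; beyond the scatter) from compound 1 to compound 3 and a 110-fold higher number (2.03 log units; beyond the scatter) from compound 2 to compound 4, 4.1-fold (0.62 log units) apart, beyond the scatter of two such steps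

An ester, an amide or a plain butyl chain at this place could show whether the acid itself carries the penalty. A still longer acid chain could show whether the number stays this high.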